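The source may report more compounds than this note shows. Statements on the series, on what has been measured and on what is new or still open speak of the compounds shown alone.

Working notes on the series. Compound 1 `Cc1cc(C)n(-c2nc(-c3cccnc3)cc(=O)[nH]2)n1` carries pyridin-3-yl on the shared core. In an ADME assay on CHO cells (Cricetulus griseus) for cytotoxicity, read by MTT assay (a higher number here means a weaker inhibitor, a lower number a stronger inhibitor), compound 1 returns only a limit of the assay, > 50000 nM, and no number. Compound 2 `CCNc1cc(C)nn1-c1nc(C(F)(F)F)cc(=O)[nH]1` carries trifluoromethyl in the place where compound 1 carries pyridin-3-yl. In this assay compound 2 gives 8000 nM. Among the measured compounds shown here, this is the only number in the set so far; the other value is a limit, (the limit of > 50000 nM in this assay, at which 1 of the 2 values shown sits), so compound 2 stands alone as the one compound with a measured concentration. Compound 3 `CCNc1cc(C)nn1-c1nc(-c2cccnc2)cc(=O)[nH]1` keeps the rest of compound 2 unchanged and takes the change (pyridin-3-yl in place of trifluoromethyl on an aromatic carbon). For the measured compounds named here, no measured step covers this change directly. The expectation rests on compound 1, which holds the same pyridin-3-yl and sits at the limit > 50000 nM in this assay; on that basis the step is expected to be a 3.8-fold higher number from compound 2 to compound 3 (0.57 log units; beyond the scatter), that is, beyond the scatter and toward weaker inhibition. For compound 3 the estimate in this assay is 30000 nM, expected to fall within 10000 nM to 100000 nM, with a real chance that the assay reports only a limit.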

Compound 3, half-maximal inhibitory concentration: > 50000 nM
Compound 3: no number, only a limit; the forecaster's own chance of this, stated with the estimate: 45%; middle value at least 1.6-fold (0.22 log units) from the limit.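

With ethylamino held fixed, this assay now gives a direct reading of pyridin-3-yl in place of trifluoromethyl on this aromatic carbon, with an at least 6.2-fold higher number from compound 2 to compound 3 (0.79 log units; beyond the scatter) as the step, toward weaker inhibition. Compound 3 returns a limit and no number, so this step has a lower bound and no exact size. Compound 1 and compound 3 both carry pyridin-3-yl and differ in holding methyl or ethylamino, yet their limits leave the step between them unreadable, and ethylamino does not bring compound 3 to a measured concentration: the limit of > 50000 nM in this assay, at which 2 of the 3 values shown sit.

With compound 2 the only compound giving a number, the compounds shown leave open how far the two pyridin-3-yl compounds lie beyond the limit, and whether ethylamino has any effect on the number when trifluoromethyl is present. A phenyl ring or a plain methyl at this aromatic carbon, with ethylamino kept, would show whether the step follows the arrival of a ring, its ring nitrogen, or the departure of trifluoromethyl.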